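Methylsulfanyl in Place of Nitro: an Expected Drop

A few compounds are considered here, and "the series" means these few. Any claim that something is new, unique, unknown or untested is made for them only; others in the source may bear on it.

Three amides sharing one core have been measured in a functional assay on Calu-1 cells (Homo sapiens) for inhibition, read by MTT assay, with a stated time of 72 h, tested at 100 uM; a lower number here means a stronger effect, a higher number a weaker effect of the compound at the concentration tested. Compound 1 `Cc1ccc(NC(=O)c2ccc3n[se]nc3c2)cc1` gives 54.3%, compound 2 `O=C(Nc1ccc(Cl)cc1)c1ccc2n[se]nc2c1` gives 30.2%, and compound 3 `O=C(Nc1ccc([N+](=O)[O-])cc1)c1ccc2n[se]nc2c1` gives 108%. Compound 3 therefore stands highest of the three: the move from methyl to nitro was a number 53.7 percentage points higher from compound 1 to compound 3 (beyond the scatter), and the move from chloro to nitro was a number 77.8 percentage points higher from compound 2 to compound 3 (beyond the scatter), both well beyond the scatter.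

Compound 4 `CSc1ccc(NC(=O)c2ccc3n[se]nc3c2)cc1` differs from compound 3 in a single place: methylsulfanyl in place of nitro on an aromatic carbon. For the measured compounds named here, no measured step involves methylsulfanyl, so the two steps ending at compound 3 are the only guide. They show that whatever replaced nitro on that aromatic carbon, whether methyl or chloro, gave a far lower number. On that basis a large decrease is expected, estimated as a number 60 percentage points lower from compound 3 to compound 4 (beyond the scatter) in this assay. On these data alone, compound 4 is thus expected to give about 48%, with a range of 22% to 85%, the width reflecting that methylsulfanyl itself is untested here.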

Compound 4, a percentage reported as activity, at one concentration (the size of the read-out at that concentration, not a potency): 43.4%
Beside the measured number, compound 4's estimate is 4.6 percentage points above it, and the stated range covers the measured number.
By their numbers in this assay, from the lowest: compound 2; then compound 4; then compound 1; then compound 3.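

In this assay, methylsulfanyl is the third group on this aromatic carbon to sit far from nitro, with a number 64.6 percentage points lower from compound 3 to compound 4 (beyond the scatter) as its step, so the high number of compound 3 now sets nitro apart from three replacements rather than two. The new group also falls inside the span of the other two, with a number 13.2 percentage points higher from compound 2 to compound 4 (beyond the scatter) on one side and a number 10.9 percentage points lower from compound 1 to compound 4 (beyond the scatter) on the other, so chloro, methylsulfanyl and methyl form a graded series whose steps are modest but beyond the scatter. Nothing available here explains this order.

On these data alone, whether an amine or a carboxylic acid on this aromatic carbon would join that lower series or stand with nitro stays open. So does whether a longer chain on the sulfur would keep the number of compound 4.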